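Bromo for piperidinyloxy on the chromone series

This account rests on a few compounds, and the source may have more. Where it says the series, first, only, none or still open, it means among the compounds named here.

In a functional assay (Homo sapiens) for antiproliferative activity, read by resazurin assay, with a stated time of 48 h, tested at 10 uM (a lower number here means a weaker effect, a higher number a stronger effect of the compound at the concentration tested), compound 2 `COc1cc(OC)c2c(=O)cc(-c3ccc(OC4CCN(C)CC4)cc3)oc2c1` gives 49% and stands highest of the two numbers recorded; compound 3 `COc1cc(OC)c2c(=O)cc(-c3ccc(OCCCN)cc3)oc2c1` gives 39%, and the step of a number 10 percentage points lower from compound 2 to compound 3 (within the scatter) is within the scatter. Compound 1 `COc1cc(OC)c2c(=O)cc(-c3ccc(OCCF)cc3)oc2c1` is reported as "not active" (no number reported), without a number. Compound 4 `COc1cc(OC)c2c(=O)cc(-c3ccc(Br)cc3)oc2c1` differs from compound 2 by bromo in place of (1-methylpiperidin-4-yl)oxy on an aromatic carbon. Among the compounds with values here, no measured step removes the nitrogen-bearing group; the one step on the ether group stays between two such groups and is within the scatter. Within the data shown here, the only compound without such a group, compound 1, is not active in this assay. For compound 4 the step expected in this assay is therefore estimated as a number 34 percentage points lower from compound 2 to compound 4 (beyond the scatter). The estimate for compound 4 is 15%, in the range 0% to 40%.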

Compound 4, a percentage reported as inhibition, at one concentration (the size of the read-out at that concentration, not a potency): 10%
Beside the measured number, compound 4's estimate is 5 percentage points above it, and the stated range covers the measured number.
By their numbers in this assay, from the lowest: compound 4; then compounds 3 and 2 (each within the scatter of the next).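

In this assay, within the data shown here, bromo on this aromatic carbon gives a number 39 percentage points lower from compound 2 to compound 4 (beyond the scatter) and a number 29 percentage points lower from compound 3 to compound 4 (beyond the scatter) and both lie beyond the scatter, making this the first change here that clearly moves the read-out. Both nitrogen-bearing ethers, the (1-methylpiperidin-4-yl)oxy and the 3-aminopropoxy, hold numbers above that of compound 4, though the step between those two stayed within the scatter. No measurement given here accounts for these steps.

Going by these compounds, whether the nitrogen itself or merely the ether chain carries the effect stays open: a cyclohexyloxy or plain propoxy group on this carbon would separate the two.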